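Isopropoxycarbonyl in place of butyl: expected solubility of compound 3

This account rests on a few compounds, and the source may have more. Where it says the series, first, only, none or still open, it means among the compounds named here.

Within the data shown here, in a physicochemical assay for solubility, read by HPLC, in phosphate buffer, with a stated time of 24 h, at 20 degrees C, at pH 7.4 (a higher number here means a more soluble compound, a lower number a less soluble compound), compound 2 (`CCCCN1CC(CC(=O)NO)(NS(=O)(=O)c2ccc(OCc3cc(C)nc4ccccc34)cc2)C1`) gives 70000 nM as the only actual number so far. Compound 1 (`CC(=O)N1CC(CC(=O)NO)(NS(=O)(=O)c2ccc(OCc3cc(C)nc4ccccc34)cc2)C1`) gives < 500 nM as a limit of the assay and not a number. Among the measured compounds shown here, the one measured step is an at least 140-fold higher number from compound 1 to compound 2 (2.14 log units; beyond the scatter) and it is large and beyond the scatter, with butyl in place of acetyl on an amine nitrogen in a ring. Compound 3 (`Cc1cc(COc2ccc(S(=O)(=O)NC3(CC(=O)NO)CN(C(=O)OC(C)C)C3)cc2)c2ccccc2n1`) has isopropoxycarbonyl in place of butyl on that nitrogen (isopropoxycarbonyl in place of butyl on an amine nitrogen in a ring). Butyl leaves here, so that single step is read in reverse and a large fall is expected in this assay for this change. The estimated step is an 88-fold lower number from compound 2 to compound 3 (1.94 log units; beyond the scatter) in all. Compound 3 is expected at 800 nM with an estimated range from 200 nM to 8000 nM and a limit in place of a number is also expected to be possible.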

Compound 3, solubility: 80000 nM
The estimate for compound 3 lay 100-fold (2.00 log units) below the measured number; the whole stated range lies below it.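

In this assay, a carbonyl on this amine nitrogen in a ring does not by itself go with a low reading, as isopropoxycarbonyl in place of butyl gives a 1.1-fold higher number from compound 2 to compound 3 (0.06 log units; within the scatter). With the carbonyl kept, isopropoxy in place of methyl on a carbonyl carbon gives an at least 160-fold higher number from compound 1 to compound 3 (2.20 log units; beyond the scatter), so among these compounds the low reading belongs to acetyl alone. Compound 1 gives a limit and not a number, so that step has no upper end: the limit of < 500 nM in this assay, at which 1 of the 3 values shown sits.

As far as these compounds go, whether methoxycarbonyl or a urea on this nitrogen reads with compound 1 or with compound 3 remains open. From the compounds shown here alone, what sets acetyl apart also remains open.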